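Fluoro in place of chloro on an aromatic carbon

This account rests on a few compounds, and the source may have more. Where it says the series, first, only, none or still open, it means among the compounds named here.

In an ADME assay on MT2 cells (Homo sapiens) for cytotoxicity, read by XTT assay, with a stated time of 4 days (a higher number here means that more compound is tolerated, a lower number that less compound is tolerated), compound 1 (`Cc1ccc(NC(=O)C(=O)NC(c2nc(C)c(CCO)s2)C2CCCCN2)cc1F`) gives 85000 nM and compound 2 (`Cc1nc(C(NC(=O)C(=O)Nc2ccc(F)cc2)C2CCCCN2)sc1CCO`) gives 109000 nM while compound 3 (`Cc1nc(C(NC(=O)C(=O)Nc2ccc(F)c(Cl)c2)C2CCCCN2)sc1CCO`) gives 94700 nM as a value within the scatter of both others. Compound 4 (`Cc1nc(C(NC(=O)C(=O)Nc2ccc(F)c(F)c2)C2CCCCN2)sc1CCO`) carries one change from compound 3 (fluoro in place of chloro on an aromatic carbon), fluoro in place of chloro on an aromatic carbon. The nearest measured change, chloro in place of hydrogen on an aromatic carbon (a 1.2-fold lower number from compound 2 to compound 3 (0.06 log units; within the scatter)), stayed within the scatter, as did both replacements of 3-fluoro-4-methylphenyl (a 1.3-fold higher number from compound 1 to compound 2 (0.11 log units; within the scatter)) and (a 1.1-fold higher number from compound 1 to compound 3 (0.05 log units; within the scatter)). No step beyond the scatter is therefore expected in this assay for this change. The expected change is small (a 1.1-fold higher number from compound 3 to compound 4 (0.02 log units; within the scatter)). Compound 4 is estimated at 100000 nM with an expected range from 60000 nM to 170000 nM in this measurement.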

Compound 4, half-maximal cytotoxic concentration: > 78200 nM
Compound 4: only a limit was reported (the forecaster's own chance of this, stated with the estimate: 15%); the middle value lies beyond the limit too.
By their numbers in this assay, from the lowest: compounds 1, 3 and 2 (each within the scatter of the next).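

In this assay compound 4 gives only a limit, > 78200 nM and its steps from compounds 1, 2 and 3 cannot be read. Going by these compounds, whether fluoro in place of chloro on an aromatic carbon shifts this number beyond the scatter stays open.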